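The source may hold more compounds than are shown below. What is called first, only, known or untested is meant among the compounds shown, and "the series" means these compounds.

Three measured compounds in an assay on isolated protein for inhibition of MAP kinase-activated protein kinase 5 (Homo sapiens), read by mobility shift assay, tested at 30 uM; on this read-out lower numbers stand for less inhibition and higher numbers for more inhibition at the one concentration tested (going by the name of the read-out):
compound 1 `COc1ccc(-c2cc3[nH]nc(N)c3c(=O)[nH]2)cc1` gives 7%;
compound 2 `CN1CCN(c2ccc(-c3cc4[nH]nc(N)c4c(=O)[nH]3)cc2)CC1` gives 11%;
compound 3 `COc1ccc(-c2cc3nn(-c4ccccc4)c(N)c3c(=O)[nH]2)cc1` gives 12%.

Compound 1 and compound 2 share one core and differ in a single place: 4-methylpiperazin-1-yl in place of methoxy on an aromatic carbon. That change produced a number 4 percentage points higher from compound 1 to compound 2 (within the scatter), so the two readings are not really told apart. Compound 3 carries another core; how that core differs from the core of compound 1 is not broken down here. Compound 4 `CN1CCN(c2ccc(-c3cc4nn(-c5ccccc5)c(N)c4c(=O)[nH]3)cc2)CC1` is not yet measured and stands to compound 3 as compound 2 stands to compound 1, the change being (4-methylpiperazin-1-yl in place of methoxy on an aromatic carbon). Both changes sit on the same kind of place, so this is the same change made on a second core. Since on the first core it gave a number 4 percentage points higher from compound 1 to compound 2 (within the scatter), a small step is expected again, a number 3 percentage points higher from compound 3 to compound 4 (within the scatter). The pair of cores themselves gave values within the scatter of each other, so nothing argues for a different outcome. For compound 4 the expected reading in this assay is 15%, between 5% and 28%.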

Compound 4, a percentage reported as inhibition, at one concentration (the size of the read-out at that concentration, not a potency): 4%
Estimate against measurement, compound 4: 11 percentage points above, and the stated range ends above it.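

In this assay, putting 4-methylpiperazin-1-yl in place of methoxy on the second core gave a number 8 percentage points lower from compound 3 to compound 4 (within the scatter), so on this core, as on the first, the change does not clearly separate the two readings. Set side by side, the two steps cannot be told apart: the same change on two cores in this assay, a number 4 percentage points higher (within the scatter) from compound 1 to compound 2 and a number 8 percentage points lower (within the scatter) from compound 3 to compound 4, 12 percentage points apart, within the scatter of two such steps. This shows no sign that the core alters the outcome of this change, but it does not show that a real effect carries from one core to the other: all four readings lie close to the low end of the scale at a single concentration, and a small effect on either core could stay hidden in the scatter.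

The compounds shown leave open what other groups in this place would do, such as a carboxylic acid, a simple amine or a longer chain ending in an amine. They also leave open whether any compound of this series gives a reading clearly beyond the scatter of these four, which a firmer test of carrying a change between cores would need.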